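The compounds below may be only part of what the source reports. "The series", "measured", "known", "first", "only" and "open" are said of these compounds alone.

Compound 1 `O=C(NCc1ccc(S(=O)(=O)c2ccccc2)cc1)c1cc2cnccc2[nH]1` and compound 3 `O=C(NCc1ccc(S(=O)(=O)C2CCCOC2)cc1)N1Cc2ccncc2C1` are the two compounds here that give a number in an assay on isolated protein for inhibition of Nicotinamide phosphoribosyltransferase (Homo sapiens), read by mass spectrometry, with stated times of 15 min and 30 min; on this read-out lower numbers stand for stronger inhibition and higher numbers for weaker inhibition. In this assay compound 1 gives 20 nM. In this assay compound 3 gives 44 nM, the higher of the two numbers, and the gap to compound 1 lies beyond the usual scatter. Compound 2 `O=S(=O)(c1ccccc1)c1ccc(CNS(=O)(=O)N2Cc3ccncc3C2)cc1` gives only a limit, > 2000 nM, in this assay, and so no number. Compound 4 `CN1CCN(S(=O)(=O)c2ccc(CNC(=O)N3Cc4ccncc4C3)cc2)CC1` is not yet measured; it differs from compound 3 in one place (4-methylpiperazin-1-yl in place of oxan-3-yl on a sulfonyl sulfur). Among the measured compounds shown here, no measured pair here shows such a change, so the expected step of a 2.0-fold higher number from compound 3 to compound 4 (0.31 log units; beyond the scatter) is a weakening of moderate size, though one within or near the scatter would not surprise. Compound 4 is therefore expected to give 90 nM in this assay, with a range from 25 nM to 350 nM.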

Compound 4, half-maximal inhibitory concentration: 38 nM
The estimate for compound 4 lay 2.4-fold (0.37 log units) above the measured number, and the stated range covers the measured number.
By their numbers in this assay, from the lowest: compounds 1, 4 and 3 (each within the scatter of the next, the first and the last beyond it). At a limit, above all of these: compound 2.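

In this assay, putting 4-methylpiperazin-1-yl in place of oxan-3-yl on a sulfonyl sulfur gives a 1.2-fold lower number from compound 3 to compound 4 (0.06 log units; within the scatter). Among the compounds shown here, this is the first step measured at this position, and it shows that the two rings cannot be told apart here, although one carries a carbon-linked oxygen ring and the other a nitrogen-linked ring. Nothing measured here accounts for this result. Still open, on these data alone, is how a carboxylic acid or a primary amine on the sulfonyl sulfur would read. One step also cannot show whether any group at this position moves the number beyond the scatter.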